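Aryl amides on a shared core: adenosine receptor binding

This account rests on a few compounds, and the source may have more. Where it says the series, first, only, none or still open, it means among the compounds named here.

Measured compounds in an assay on CHO cells for displacement of a labelled ligand from adenosine receptor A1 (Homo sapiens), tested at 10 uM; on this read-out higher numbers stand for more inhibition at the one concentration tested (going by the name of the read-out) and lower numbers for less inhibition:
compound 1 `COc1ccc(OC)c(NC(=O)Nc2nn(-c3ccccc3)c(=O)c3ccccc23)c1`, 0%
compound 2 `O=C(Nc1ccc(Cl)cc1)Nc1nn(-c2ccccc2)c(=O)c2ccccc12`, 10%
compound 3 `COc1ccc(C(=O)Nc2nn(-c3ccccc3)c(=O)c3ccccc23)cc1`, 0%

Compound 3 stands level with compound 1 at the digits reported, the two together the lowest of the three numbers; compound 2 is nearest above, and that gap is within the scatter. Within the data shown here, the steps so far, a number 10 percentage points higher from compound 1 to compound 2 (within the scatter) and a number 10 percentage points lower from compound 2 to compound 3 (within the scatter), both stay within the scatter.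

Compound 4 `O=C(Nc1nn(-c2ccccc2)c(=O)c2ccccc12)c1ccco1` is not yet measured. It differs from compound 3 as furan-2-yl in place of 4-methoxyphenyl on a carbonyl carbon. The step from compound 2 to compound 3 also changed the group on the carbonyl carbon and moved nothing beyond the scatter, so no step beyond the scatter is expected for compound 4 in this assay, that is a number 3 percentage points higher from compound 3 to compound 4 (within the scatter). Compound 4 is estimated at 3%, in the range 0% to 15%.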

Compound 4, a percentage reported as inhibition, at one concentration (the size of the read-out at that concentration, not a potency): 23%
For compound 4 the middle estimate is 20 percentage points below the measured one; the whole stated range lies below it.
By their numbers in this assay, from the lowest: compounds 1, 3 and 2 (each within the scatter of the next); then compound 4.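

In this assay, among these compounds, the group on the carbonyl carbon now matters: furan-2-yl in place of 4-methoxyphenyl gives a number 23 percentage points higher from compound 3 to compound 4 (beyond the scatter) and furan-2-yl in place of (4-chlorophenyl)amino gives a number 13 percentage points higher from compound 2 to compound 4 (beyond the scatter) as the only steps beyond the scatter. The position is therefore not indifferent to its substituent, although the earlier change on this carbon stayed within the scatter. Nothing at hand accounts for the rise.

From the compounds shown here alone, whether it belongs to furan-2-yl alone stays open, as does what thiophen-2-yl or tetrahydrofuran-2-yl would give on this carbon. A reading at one concentration also leaves potency open.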